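Replacing an aryl group with tert-butyl on the imidazole side chain

The source may report more compounds than this note shows. Statements on the series, on what has been measured and on what is new or still open speak of the compounds shown alone.

Measured compounds:
compound 1 `CCCCc1cnc(C(CCC)Cc2ccc(-c3ccccc3C(=O)O)cc2)[nH]1`: 1180 nM
compound 2 `COc1cccc(Cc2cnc(CCc3ccc(-c4ccccc4C(=O)O)cc3)[nH]2)c1`: 4120 nM
compound 3 `CCC(C)(C)Cc1c[nH]c(CCc2ccc(-c3ccccc3C(=O)O)cc2)n1`: 25 nM

In an in vitro functional assay on cells for agonist activity at Bombesin receptor subtype-3 (Homo sapiens), read by luminescence and calcium flux (a lower number here means that less compound is needed, a higher number that more compound is needed for the effect), compound 2 gives 4120 nM, the highest of the three numbers; compound 1 lies nearest to it with a lower number, and compound 3 lies furthest, its number far lower, both differences beyond the scatter. Compound 3, which carries a branched alkyl group on the shared core, is the most potent of the three.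

The unmeasured compound 4 `CC(C)(C)Cc1cnc(CCc2ccc(-c3ccccc3C(=O)O)cc2)[nH]1` is compound 2 with a single change: tert-butyl in place of 3-methoxyphenyl on a saturated chain carbon bound to an aromatic carbon. Cut one bond further out, the same difference reads 3-methoxybenzyl to neopentyl. Compound 4 thereby comes to resemble compound 3 closely, the two differing only in the size of the alkyl group on the core.

The step is expected to be large and downward: the estimate implies a 52-fold lower number from compound 2 to compound 4 (1.71 log units; beyond the scatter), because compound 3 with its branched alkyl gives 25 nM in this assay. Compound 4 is therefore expected to give 80 nM, with a range from 20 nM to 400 nM.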

Compound 4, half-maximal effective concentration: 106 nM
Estimate against measurement, compound 4: 1.3-fold (0.12 log units) below; measured number inside the range.
By their numbers in this assay, from the lowest: compound 3; then compound 4; then compound 1; then compound 2.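

In this assay, tert-butyl in place of 3-methoxyphenyl on a saturated chain carbon bound to an aromatic carbon gives a 39-fold lower number from compound 2 to compound 4 (1.59 log units; beyond the scatter) and is the first change among these compounds that can be read in one place. It shows that an aromatic ring and a hydrogen-bond acceptor in the leaving group are not required at this position for a far lower number, since tert-butyl has neither. No measurement shown accounts for the size of this step.

The change removes the ring, the methoxy group and four heavy atoms at once, so the contribution of each remains unresolved. As far as these compounds go, it also remains open whether an unsubstituted phenyl or a cyclohexyl group in the same place would give a number closer to that of compound 2 or compound 4.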